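The source may report more compounds than this note shows. Statements on the series, on what has been measured and on what is new or still open speak of the compounds shown alone.

Measured in a functional assay on PC-3 cells (Homo sapiens), read by MTT assay, with a stated time of 48 h; a higher number here means a weaker inhibitor, a lower number a stronger inhibitor:
compound 1 `CCN(CC)CCNC(=O)c1ccc(C(CC)(CC)c2ccc(OCC(=O)C(C)(C)C)c(C)c2)n1CC`: 30 nM
compound 2 `CCn1c(C(=O)NCCN(C)C)ccc1C(CC)(CC)c1ccc(OCC(=O)C(C)(C)C)c(C)c1`: 2300 nM
compound 3 `CCOC(=O)CN(C)C(=O)c1ccc(C(CC)(CC)c2ccc(OCC(O)C(C)(C)C)c(C)c2)n1CC`: 25500 nM

Compound 3 has the highest number of the three, beyond the scatter from both of the others. Compound 4 `CCN(CC)CCNC(=O)c1ccc(C(CC)(CC)c2ccc(OCC(O)C(C)(C)C)c(C)c2)n1CC` differs from it in one place: (2-(diethylamino)ethyl)amino in place of ((ethoxycarbonyl)methyl)(methyl)amino on a carbonyl carbon. Among the measured compounds shown here, no measured step covers this swap directly. For the measured compounds named here, the entering (2-(diethylamino)ethyl)amino is also carried by compound 1, but compound 1 differs from compound 4 elsewhere as well, and no measured step isolates that second difference. Going by the values given here, the only measured step, a 77-fold higher number from compound 1 to compound 2 (1.88 log units; beyond the scatter), is large and shows how far this assay can move with a change on this chain alone. It also leaves the diethylamino end with the lower number. A large step towards a lower number is therefore expected, though compound 4 is expected to keep a higher number than compound 1, which gives 30 nM. The expected step is a 170-fold lower number from compound 3 to compound 4 (2.23 log units; beyond the scatter). The estimated value for compound 4 is 150 nM, with an expected range of 20 nM to 1500 nM.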

Compound 4, half-maximal inhibitory concentration: 220 nM
The estimate for compound 4 lay 1.5-fold (0.17 log units) below the measured number, and the stated range covers the measured number.
By their numbers in this assay, from the lowest: compound 1; then compound 4; then compound 2; then compound 3.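

In this assay, (2-(diethylamino)ethyl)amino in place of ((ethoxycarbonyl)methyl)(methyl)amino on a carbonyl carbon gives a 120-fold lower number from compound 3 to compound 4 (2.06 log units; beyond the scatter), so this swap alone spans much of the range of the series, with 1-hydroxy-2,2-dimethylpropyl held constant. With (2-(diethylamino)ethyl)amino held constant, 1-hydroxy-2,2-dimethylpropyl in place of (tert-butyl)carbonyl gives only a 7.3-fold higher number from compound 1 to compound 4 (0.87 log units; beyond the scatter), a modest step that is smaller than the swap on the carbonyl carbon. No measurement is at hand that explains either step.

The swap on the carbonyl carbon changes the amine end, the ester and the amide hydrogen together, so the compounds shown do not assign the large step to any one of them. A (2-(diethylamino)ethyl)(methyl)amino group, a 3-(diethylamino)propyl chain on the amide nitrogen or a pyrrolidine end would test these parts separately.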